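Bromo to iodo on the sulfonamide series

The source may report more compounds than this note shows. Statements on the series, on what has been measured and on what is new or still open speak of the compounds shown alone.

Compound 1 `O=S(=O)(NCCN1CCCCC1)c1ccc(I)cc1` gives 0.46 nM in an assay on membranes from brain (Cavia porcellus) for binding affinity to Sigma non-opioid intracellular receptor 1 (Homo sapiens); a lower number here means a stronger inhibitor, a higher number a weaker inhibitor. Compound 2 `CCN(CC)CCNS(=O)(=O)c1ccc(Br)cc1` gives 10.1 nM in this assay, the highest of the two numbers measured; the two compounds differ in more than one place, so only their values are compared. Compound 3 `CCN(CC)CCNS(=O)(=O)c1ccc(I)cc1` is not yet measured; it carries iodo in place of bromo on an aromatic carbon. Among the measured compounds shown here, with no measured step of this kind available, a moderate step toward a lower number is expected, beyond the scatter. Compound 3 is estimated at 3 nM, between 1 nM and 10 nM, meaning an expected step of a 3.4-fold lower number from compound 2 to compound 3 (0.53 log units; beyond the scatter).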

Compound 3, inhibition constant: 4.97 nM
Compound 3: middle estimate off by 1.7-fold (0.22 log units), on the low side; measured number inside the range.
By their numbers in this assay, from the lowest: compound 1; then compound 3; then compound 2.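

In this assay, iodo in place of bromo on an aromatic carbon, para to a large group, gives a 2.0-fold lower number from compound 2 to compound 3 (0.31 log units; beyond the scatter), so this position responds modestly to the change of halogen. With iodo held in place, diethylamino in place of piperidin-1-yl gives an 11-fold higher number from compound 1 to compound 3 (1.03 log units; beyond the scatter), a larger step than the halogen change. Nothing available explains either step.

As far as these compounds go, it remains open whether the step from bromo to iodo is of similar size in compounds carrying piperidin-1-yl. From the compounds shown here alone, how a chloro or methoxy group at the same position would compare also remains open.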